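Chloro to Nitro Swap on an Enone Chalcone Amide

This account rests on a few compounds, and the source may have more. Where it says the series, first, only, none or still open, it means among the compounds named here.

Measured compounds and their cytotoxicity numbers:
- compound 1, `O=C(CCl)Nc1ccc(C(=O)/C=C/c2ccc(Cl)cc2)cc1`: 8340 nM
- compound 2, `O=C(CCl)Nc1ccc(C(=O)/C=C/c2cccc(Cl)c2)cc1`: 5560 nM
- compound 3, `O=C(CSC(=S)N[C@H]1CCOC1=O)Nc1ccc(C(=O)/C=C/c2ccc(Cl)cc2)cc1`: 38900 nM

These numbers come from a functional assay on EC9706 cells (Homo sapiens) for cytotoxicity, read by MTT assay, with a stated time of 72 h; on this read-out higher numbers stand for weaker inhibition and lower numbers for stronger inhibition. Compound 3 gives the highest of the three numbers; the step of a 4.7-fold higher number from compound 1 to compound 3 (0.67 log units; beyond the scatter) is modest, and the step of a 1.5-fold lower number from compound 1 to compound 2 (0.18 log units; within the scatter) lies within the scatter.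

Compound 4, `O=C(CSC(=S)N[C@H]1CCOC1=O)Nc1ccc(C(=O)/C=C/c2ccc([N+](=O)[O-])cc2)cc1`, differs from compound 3 by nitro in place of chloro on an aromatic carbon. For the measured compounds named here, no measured step touches this position in this way; the only change on that ring, from compound 1 to compound 2, moved the chloro and stayed within the scatter. A step of no more than the scatter is therefore expected, in no firm direction, so a 1.1-fold lower number from compound 3 to compound 4 (0.05 log units; within the scatter) is estimated. Compound 4 is expected to give about 35000 nM in this assay, between 12000 nM and 100000 nM.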

Compound 4, half-maximal inhibitory concentration: > 128000 nM
Compound 4: only a limit was reported; the forecaster's own chance of this, stated with the estimate: 10%; at least 3.6-fold (0.56 log units) between middle value and limit.
By their numbers in this assay, from the lowest: compounds 2 and 1 (each within the scatter of the next); then compound 3. At a limit, above all of these: compound 4.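

Swapping 4-chlorophenyl for 4-nitrophenyl gives an at least 3.2-fold higher number from compound 3 to compound 4 (0.51 log units; beyond the scatter). This shows that cytotoxicity responds to which group sits at this place on the ring, something that moving the chloro, in a 1.5-fold lower number from compound 1 to compound 2 (0.18 log units; within the scatter), did not reveal. The number for compound 4 is a limit, not a measured value: the limit of > 128000 nM in this assay, at which 1 of the 4 values shown sits.

The compounds shown leave open how an amine or a carboxylic acid at this place would compare with chloro and nitro. As far as these compounds go, it also remains open whether nitro in place of chloro would give a similar step on compound 1, which carries the chloroacetyl chain instead.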